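The source may report more compounds than this note shows. Statements on the series, on what has been measured and on what is new or still open speak of the compounds shown alone.

Working notes on the catechol–thiophene sulfonamide series, cytotoxicity.

Compound 1 `CC(C)c1ccc(Oc2ccc(O)c(O)c2)c(-c2ccsc2S(=O)(=O)NCCNC(=S)Nc2ccc([N+](=O)[O-])cc2)c1` carries a thiourea linked to a nitrophenyl group; in an ADME assay on HEK-293T cells (Homo sapiens) for cytotoxicity, read by CCK-8 assay, with a stated time of 48 h (a higher number here means a weaker inhibitor, a lower number a stronger inhibitor), compound 1 gives 16300 nM. Compound 2 `Cc1ccc(-c2ccsc2S(=O)(=O)NCCNC(=S)Nc2ccc([N+](=O)[O-])cc2)c(Oc2ccc(O)c(O)c2)c1` shares that thiourea arm on a different core; the difference between the two cores is not broken down here. In this assay compound 2 gives 8200 nM, which stands within the scatter of compound 1, so the two are read as the same.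

Compound 3 `CC(C)c1ccc(Oc2ccc(O)c(O)c2)c(-c2ccsc2S(=O)(=O)NCCNC(=O)Nc2cc(Cl)cc(Cl)c2)c1` replaces the arm by the change (a group of 11 heavy atoms (7 carbon, 1 nitrogen, 1 oxygen, 2 chlorine; one six-membered aromatic ring of carbon only) in place of a group of 12 heavy atoms (7 carbon, 2 nitrogen, 2 oxygen, 1 sulfur; one six-membered aromatic ring of carbon only), on an amine nitrogen). In this assay compound 3 returns only a limit, > 10000 nM. The step that the limit leaves unreadable from compound 1 to compound 3 is therefore not readable, because the limit of > 10000 nM in this assay, at which 1 of the 3 values shown sits, hides where compound 3 actually sits.

Compound 4 `Cc1ccc(-c2ccsc2S(=O)(=O)NCCNC(=O)Nc2cc(Cl)cc(Cl)c2)c(Oc2ccc(O)c(O)c2)c1` is not yet measured. It arises from compound 2 by the same kind of change, (a group of 11 heavy atoms (7 carbon, 1 nitrogen, 1 oxygen, 2 chlorine; one six-membered aromatic ring of carbon only) in place of a group of 12 heavy atoms (7 carbon, 2 nitrogen, 2 oxygen, 1 sulfur; one six-membered aromatic ring of carbon only), on an amine nitrogen), now set on the core of compound 2; the place lines of both changes read the same word for word. Within the data shown here, the only precedent for this change, from compound 1 to compound 3, ends at a limit, so no size can be carried over. What is expected is that compound 4 behaves like compound 3 and stays at or past the limit, with a step of a 1.8-fold higher number from compound 2 to compound 4 (0.26 log units; within the scatter) estimated from compound 2. For compound 4 the estimate in this assay is 15000 nM, between 6000 nM and 40000 nM.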

Compound 4, half-maximal inhibitory concentration: 6700 nM
Compound 4: the middle estimate sits 2.2-fold (0.35 log units) above what was measured; measured number inside the range.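

On the core of compound 2, the change from the thiourea arm to the (3,5-dichlorophenyl)carbamoyl group in this assay gives a 1.2-fold lower number from compound 2 to compound 4 (0.09 log units; within the scatter), so the two arms cannot be told apart on this core. The size of the same change on the core of compound 1 cannot be read, because compound 3 stands at a limit of the assay: the limit of > 10000 nM in this assay, at which 1 of the 4 values shown sits. Among these compounds, this leaves one readable instance of the change and no second step to set beside it, so the result does not show whether the size of the step carries from one core to the other, only that no step beyond the scatter appears on the core of compound 2.

The entering group differs from the leaving one at two points at once, the thiocarbonyl becoming a carbonyl and the nitrophenyl ring becoming a dichlorophenyl ring, and the compounds shown do not separate these two parts of the change. Also open, going by these compounds, is how this assay would read with an amine or a carboxylic acid on the phenyl ring of the arm, or with a longer chain leading to the amine nitrogen.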